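A Sulfone in Place of an Alkenyl Ether

A few compounds are considered here, and "the series" means these few. Any claim that something is new, unique, unknown or untested is made for them only; others in the source may bear on it.

Compound 1 `COc1ccc(/C=C/C(=O)c2ccc(OC)c3c2OC(C)(C)C=C3)cc1OCC=C(C)C` — > 10000 nM in a functional assay on A-375 cells (Homo sapiens) for cytotoxicity, read by MTT assay (on this read-out lower numbers stand for stronger inhibition and higher numbers for weaker inhibition), a limit
Compound 2 `C=CCOc1cc(/C=C/C(=O)c2ccc(OC)c3c2OC(C)(C)C=C3)ccc1OC` — > 10000 nM in this assay, a limit

In this assay compound 1 gives > 10000 nM, which is a limit of the assay rather than a number. Compound 2 likewise gives > 10000 nM, again a limit. Within the data shown here, the one measured step, a step that the two limits leave unreadable from compound 1 to compound 2, cannot be read in size or direction, since the limit of > 10000 nM in this assay, at which 2 of the 2 values shown sit, shows that both values sit at the same limit. Compound 1 thus stands at the limit, with no readable number around it.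

Compound 3 `COc1ccc(/C=C/C(=O)c2ccc(OC)c3c2OC(C)(C)C=C3)cc1CS(C)(=O)=O` has not yet been measured. It differs from compound 1 by (methylsulfonyl)methyl in place of (3-methylbut-2-en-1-yl)oxy on an aromatic carbon. Among the measured compounds shown here, no measured step involves this kind of change, and the only step at hand, from compound 1 to compound 2, is itself unreadable. Nothing here gives a size or a direction to expect. Compound 3 is therefore expected to come back at the same limit, so that the step that the limit leaves unreadable from compound 1 to compound 3 is expected to be no more than nominal. The estimate for compound 3 is 15000 nM, between 4000 nM and 60000 nM, most likely reported as a limit rather than a number.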

Compound 3, half-maximal inhibitory concentration: > 10000 nM
Compound 3 was reported as a limit; the forecaster's own chance of this, stated with the estimate: 70%; the middle value does not contradict the limit.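

In this assay compound 3 gives > 10000 nM, again a limit and not a number. Among these compounds, no step among compound 1, compound 2 and compound 3 can therefore be read, since all three stand at the same limit: the limit of > 10000 nM in this assay, at which 3 of the 3 values shown sit.

The compounds shown leave open whether (methylsulfonyl)methyl, allyloxy and (3-methylbut-2-en-1-yl)oxy differ at all in this assay.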